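The source may hold more compounds than are shown below. What is called first, only, known or untested is meant among the compounds shown, and "the series" means these compounds.

Measured in a functional assay on THP-1 cells (Homo sapiens) for inhibition, with a stated time of 48 h, tested at 50 uM; on this read-out lower numbers stand for less inhibition of growth and higher numbers for more inhibition of growth at the one concentration tested:
compound 1, `C=C[C@@](C)(/C=C/c1ccc(OC(C)=O)cc1)CCC=C(C)C`: 81%
compound 2, `C=C[C@@](C)(/C=C/c1ccc(OC(=O)CCCCCCC)cc1)CCC=C(C)C`: 62%
compound 3, `C=C[C@@](C)(/C=C/c1ccc(OC(=O)CCCCCCCCC)cc1)CCC=C(C)C`: 52%

The three compounds share one core and differ only in the ester chain. Compound 2 arises from compound 1 by hexyl in place of hydrogen on a saturated chain carbon bound to a carbonyl carbon, and this change gives a number 19 percentage points lower from compound 1 to compound 2 (beyond the scatter). Compound 3 arises from compound 1 by octyl in place of hydrogen on a saturated chain carbon bound to a carbonyl carbon, giving a number 29 percentage points lower from compound 1 to compound 3 (beyond the scatter); between the two longer chains the step is a number 10 percentage points lower from compound 2 to compound 3 (within the scatter). Compound 4, `C=C[C@@](C)(/C=C/c1ccc(OC(=O)CCCCCCCCCCCCCCC)cc1)CCC=C(C)C`, has not yet been measured in this assay. It arises from compound 3 by hexyl in place of hydrogen on a saturated chain carbon, nine bonds along the chain from a carbonyl carbon. Among the compounds with values here, this is the same kind of change as the one from compound 1 to compound 2, but not the same: there the hexyl entered on a saturated chain carbon bound to a carbonyl carbon, here it enters on a saturated chain carbon nine bonds along the chain from a carbonyl carbon. Resting on the earlier step of a number 19 percentage points lower from compound 1 to compound 2 (beyond the scatter) and on the smaller step of a number 10 percentage points lower from compound 2 to compound 3 (within the scatter), the account expects in this assay a step of a number 14 percentage points lower from compound 3 to compound 4 (beyond the scatter). Compound 4 is therefore estimated at 38%, between 20% and 55%.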

Compound 4, percent growth inhibition at one concentration: 62%
Beside the measured number, compound 4's estimate is 24 percentage points below it; measured number outside the range, above it.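

In this assay the hexyl change gives a number 10 percentage points higher from compound 3 to compound 4 (within the scatter) and the octyl change gives no change at the digits printed from compound 2 to compound 4 (within the scatter), and the hexyl change does not repeat its earlier reading: the same change on two cores in this assay, a number 19 percentage points lower (beyond the scatter) from compound 1 to compound 2 and a number 10 percentage points higher (within the scatter) from compound 3 to compound 4, 29 percentage points apart, beyond the scatter of two such steps. The octyl change likewise reads differently on the two cores: the same change on two cores in this assay, a number 29 percentage points lower (beyond the scatter) from compound 1 to compound 3 and no change at the digits printed (within the scatter) from compound 2 to compound 4, 29 percentage points apart, beyond the scatter of two such steps. This shows that a step measured on the short ester of compound 1 does not carry over to a core that already holds a long ester chain, but it does not show why, and it gives no order among compound 2, compound 3 and compound 4, whose steps to one another all lie within the scatter.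

The compounds shown leave open how ester chains of intermediate length would read, and whether a chain ending in an amine or a carboxylic acid, or an amide in place of the ester, would follow the same course. Readings at a single concentration also leave open how these compounds would compare across a range of concentrations.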